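This account rests on a few compounds, and the source may have more. Where it says the series, first, only, none or still open, it means among the compounds named here.

Compound 1 `c1nc(Nc2nncc3cncn23)n[nH]1` gives 46000 nM in a functional assay for inhibition, with Homo sapiens as the target; on this read-out higher numbers stand for weaker inhibition and lower numbers for stronger inhibition.
Compound 2 `CCCc1nc(C)c2cnn(CC3CC3)c(=O)n12` gives only a limit of this assay, > 48000 nM.
Compound 3 `Cc1nc(Cc2ccccc2)n2c(O)nncc12` likewise gives only a limit, > 48000 nM.

Compound 2 thus stands at the limit of > 48000 nM in this assay, at which 2 of the 3 values shown sit, so no number is known for it. Compound 4 `CCCc1nc(C)c2cnn(CC)c(=O)n12` differs from compound 2 by a single change: methyl in place of cyclopropyl on a saturated chain carbon bound to an aromatic nitrogen. Among the measured compounds shown here, no measured step between two compounds of this set shows what such a swap does, and no property is recorded here for either group. Since compound 2 sits at the limit of > 48000 nM in this assay, at which 2 of the 3 values shown sit, the expected step that the limit leaves unreadable from compound 2 to compound 4 is none beyond the scatter. Compound 4 is therefore expected to show 60000 nM, within 20000 nM to 200000 nM, most likely again reported only as a limit.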

Compound 4, half-maximal inhibitory concentration: > 48000 nM
Compound 4: no number, only a limit; the forecaster's own chance of this, stated with the estimate: 80%; the middle value lies beyond the limit too.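

Compound 2 and compound 4 both give only a limit, so no step can be read between them: the limit of > 48000 nM in this assay, at which 3 of the 4 values shown sit.

From the compounds shown here alone, what methyl in place of cyclopropyl does to inhibition, and how weak either compound truly is, stays open.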